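Replacing a methoxy group with an aryl ether

The source may report more compounds than this note shows. Statements on the series, on what has been measured and on what is new or still open speak of the compounds shown alone.

This set of three measured compounds shares one core and differs only in the group attached to an oxygen on an aromatic ring. Compound 1 `FC(F)(F)Oc1ccc(Oc2ccnc(N3CCC(NC(=S)Nc4cccnc4)CC3)c2)cc1` carries a 4-(trifluoromethoxy)phenyl there and gives 410 nM in an assay on membranes from brain for binding affinity to Lysophosphatidylserine lipase ABHD12 (Mus musculus), read by fluorescence, with a stated time of 20 min; on this read-out lower numbers stand for stronger inhibition and higher numbers for weaker inhibition. Compound 2 `S=C(Nc1cccnc1)NC1CCN(c2cc(OCc3ccccc3)ccn2)CC1` carries a benzyl and gives 2800 nM in this assay. Compound 3 `COc1ccnc(N2CCC(NC(=S)Nc3cccnc3)CC2)c1` carries only a methyl. For compound 3 this assay reports only a limit, > 5000 nM, at the limit of > 5000 nM in this assay, at which 1 of the 3 values shown sits, so its true number is not known.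

Compound 4 `COc1ccc(Oc2ccnc(N3CCC(NC(=S)Nc4cccnc4)CC3)c2)cc1` is the next step from compound 3: 4-methoxyphenyl in place of methyl on an oxygen on an aromatic ring. The measured steps that run in the opposite direction are informative. Going from compound 1 to compound 3 gave an at least 12-fold higher number from compound 1 to compound 3 (1.08 log units; beyond the scatter), and going from compound 1 to compound 2 gave a 6.8-fold higher number from compound 1 to compound 2 (0.83 log units; beyond the scatter). Both show that shrinking the aryl ether to a methyl ether or a benzyl ether raises the number well beyond the scatter. Restoring an aryl ring in compound 4, now bearing a methoxy instead of a trifluoromethoxy, is therefore expected to lower the number by a large step, an at least 6.2-fold lower number from compound 3 to compound 4 (0.79 log units; beyond the scatter). Compound 4 is estimated at 800 nM, with a likely range from 250 nM to 3000 nM.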

Compound 4, half-maximal inhibitory concentration: 2900 nM
For compound 4 the middle estimate is 3.6-fold (0.56 log units) below the measured one; measured number inside the range.
By their numbers in this assay, from the lowest: compound 1; then compounds 2 and 4 (each within the scatter of the next). At a limit, above all of these: compound 3.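

Changing the group on the oxygen on an aromatic ring from trifluoromethyl to methyl gives a 7.1-fold higher number from compound 1 to compound 4 (0.85 log units; beyond the scatter) in this assay and so shows that an aryl ether alone does not secure the lower number of compound 1. The 4-methoxyphenyl and benzyl groups cannot be told apart on this evidence, since the step is a 1.0-fold higher number from compound 2 to compound 4 (0.02 log units; within the scatter) and no order follows from it. Whether 4-methoxyphenyl improves on methyl remains unsettled, as an at least 1.7-fold lower number from compound 3 to compound 4 (0.23 log units; that floor lies within the scatter) gives only a floor, because one end of that step is a limit and not a number: the limit of > 5000 nM in this assay, at which 1 of the 4 values shown sits.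

The compounds shown leave open whether the lower number of compound 1 depends on trifluoromethoxy specifically or would also appear with a chlorine atom, a nitrile or an ethoxy group in its place. They also leave open how a phenethyl group on the same oxygen would compare with the benzyl group of compound 2.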